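Working notes: from compound 2 to compound 3

The compounds below may be only part of what the source reports. "The series", "measured", "known", "first", "only" and "open" are said of these compounds alone.

Values in an ADME assay on HEK293 cells (Homo sapiens) for cytotoxicity, read by resazurin assay, with a stated time of 48 h (on this read-out higher numbers stand for lower toxicity in this test and lower numbers for higher toxicity in this test), so far:
- compound 1 `CS(=O)(=O)Nc1ccc(-c2nc3ccccc3o2)cc1` with > 100000 nM as a limit
- compound 2 `C=Cc1ccc(S(=O)(=O)Nc2ccc(-c3nc4ccccc4o3)cc2)cc1` with > 100000 nM as a limit

In this assay compound 2 has only a limit (> 100000 nM) and no number. Compound 3 `O=S(=O)(Nc1ccc(-c2nc3ccccc3o2)cc1)c1ccc(O)cc1` differs by hydroxy in place of vinyl on an aromatic carbon in that hydroxy takes the place of vinyl on an aromatic carbon, para to a large group.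

Among the measured compounds shown here, the only measured step bearing on this reads a step that the two limits leave unreadable from compound 1 to compound 2 and offers no size to carry over. No step beyond the scatter is expected in this assay and no direction can be given. For the measured compounds named here, a reading at the same limit is expected for compound 3 because of the limit of > 100000 nM in this assay, at which 2 of the 2 values shown sit, as the sole evidence. The estimated value for compound 3 is 100000 nM with an expected range from 40000 nM to 200000 nM around it. The expected step reads a number no higher from compound 2 to compound 3 (the limit leaves the size open) as an estimate only.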

Compound 3, half-maximal cytotoxic concentration: > 100000 nM
Compound 3 gave a limit, no number; the forecaster's own chance of this, stated with the estimate: 80%; the middle value lies on the limit itself.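

No new step can be read from compound 3, since compound 1, compound 2 and compound 3 all give only a limit in this assay: the limit of > 100000 nM in this assay, at which 3 of the 3 values shown sit.

The compounds shown leave open whether the group on the sulfonyl sulfur alters this read-out at all, and at what concentration any of them would reach half-maximal cytotoxicity.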